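Amide aryl swap: methylphenyl to pyridinyl on the shared core

The compounds below may be only part of what the source reports. "The series", "measured", "known", "first", "only" and "open" are said of these compounds alone.

Compound 2 `COc1cc2c(cc1OC)C(CC(=O)Nc1ccc(C)cc1)CC2` gives 32.8% in a functional assay on the whole organism (strain Wistar) for inhibition, with Rattus norvegicus as the target, read by paw edema, with a stated time of 4 h, at a dose of 100 mg/kg; a lower number here means less inhibition, a higher number more inhibition at the dose given (going by the name of the read-out); on these two numbers it is the lower, though only within the scatter of compound 1 `COc1cc2c(cc1OC)C(CC(=O)Nc1cccc(C)c1)CC2`, which gives 40.6%. For the measured compounds named here, the one measured step, a number 7.8 percentage points lower from compound 1 to compound 2 (within the scatter), stays within the scatter. Compound 3 `COc1cc2c(cc1OC)C(CC(=O)Nc1ccncc1)CC2` differs from compound 2 by pyridin-4-yl in place of 4-methylphenyl on an amide-type nitrogen. Going by the values given here, no measured step bears on this change, and the only step seen so far did not move the read-out beyond its scatter. A step of a number 0.2 percentage points higher from compound 2 to compound 3 (within the scatter) is therefore expected, that is none beyond the scatter. Compound 3 is estimated at 33%, with a range from 15% to 50%.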

Compound 3, a percentage reported as inhibition, in the whole organism at one dose (the size of the read-out at that dose, not a potency): 45.3%
Estimate against measurement, compound 3: 12.3 percentage points below, within the range that was stated.
By their numbers in this assay, from the lowest: compounds 2, 1 and 3 (each within the scatter of the next, the first and the last beyond it).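

For the compounds shown here, on the amide-type nitrogen, pyridin-4-yl in place of 4-methylphenyl gives the first step beyond the scatter in this assay (a number 12.5 percentage points higher from compound 2 to compound 3 (beyond the scatter)). Against 3-methylphenyl, the same group gives a step within the scatter (a number 4.7 percentage points higher from compound 1 to compound 3 (within the scatter)), so the change separates only compound 2 and compound 3. No evidence bearing on the cause of this step is available.

Open, going by these compounds, is how a piperidinyl group, or a phenyl carrying a carboxylic acid, would read on this nitrogen. Also open, on these data alone, is whether the step holds at other doses or times.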